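Methyl in place of methoxy: compound 1 to compound 4

The compounds below may be only part of what the source reports. "The series", "measured", "known", "first", "only" and "open" are said of these compounds alone.

Of the compounds shown here, three have been measured in a functional assay on the whole organism (strain BALB/c) for inhibition, with Mus musculus as the target, read by paw edema, with a stated time of 4 h, at a dose of 50 mg/kg by the oral route; a lower number here means less inhibition, a higher number more inhibition at the dose given (going by the name of the read-out). Compound 1 `COc1ccc(Nc2nnc(-c3cc(-c4ccc(F)cc4F)ccc3O)o2)cc1` gives 35.3% in this assay, the lowest of the three numbers. Compound 3 `Oc1ccc(-c2ccc(F)cc2F)cc1-c1n[nH]c(=S)n1-c1ccccc1` gives 36.3% in this assay, a number within the scatter of compound 1, so no order between these two can be read. Compound 2 `C=CCNc1nnc(-c2cc(-c3ccc(F)cc3F)ccc2O)s1` gives 57.2% in this assay, a number that lies beyond the scatter above compound 1. Within the data shown here, no two of the measured compounds differ in only one place, so no single structural step has yet been observed in this assay, and the effect of a small change on the shared core is unknown from these data.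

Compound 4 `Cc1ccc(Nc2nnc(-c3cc(-c4ccc(F)cc4F)ccc3O)o2)cc1` differs from compound 1 in one place: methyl in place of methoxy on an aromatic carbon. For this change no step beyond the scatter is expected in this assay, in either direction. The estimated step is a number 2.7 percentage points higher from compound 1 to compound 4 (within the scatter). Compound 4 is accordingly expected to give about 38% in this assay, with a range from 25% to 52%.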

Compound 4, a percentage reported as inhibition, in the whole organism at one dose (the size of the read-out at that dose, not a potency): 33.8%
The estimate for compound 4 lay 4.2 percentage points above the measured number; measured number inside the range.
By their numbers in this assay, from the lowest: compounds 4, 1 and 3 (each within the scatter of the next); then compound 2.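

In this assay the series now has its first single-place step: methyl in place of methoxy on an aromatic carbon, para to a large group, gives a number 1.5 percentage points lower from compound 1 to compound 4 (within the scatter). Going from 4-methoxyphenyl to 4-methylphenyl thus removes one oxygen and the hydrogen-bond acceptor counted for methoxy without a step beyond the scatter, so at this position and dose the read-out does not separate these two groups. No measured evidence on the origin of this step is at hand.

On these data alone, whether an amine, a carboxylic acid or a longer chain such as butoxy on this aromatic carbon would move the read-out beyond the scatter remains open. Also open, as far as these compounds go, is whether methyl in place of methoxy gives a similar step on a different core.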